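The compounds below may be only part of what the source reports. "The series", "measured", "known", "first", "only" and "open" are said of these compounds alone.

Three compounds built on one shared core were tested in an ADME assay on HepG2 cells (Homo sapiens) for cytotoxicity, read by resazurin assay, with a stated time of 24 h; a higher number here means a weaker inhibitor, a lower number a stronger inhibitor. Compound 1 `COc1cc2[nH]c(C)c(-c3ccc(Oc4cccc(OC(F)(F)F)c4)cc3)c(=O)c2cc1Cl` carries a 3-(trifluoromethoxy)phenyl on the ether oxygen. In this assay compound 1 gives > 10000 nM, which is a limit of the assay and not a number. Compound 2 `COc1cc2[nH]c(C)c(-c3ccc(Oc4ccc(Cl)cc4)cc3)c(=O)c2cc1Cl` bears a 4-chlorophenyl at the same position. In this assay compound 2 gives > 10000 nM, again only a limit. Compound 3 `COc1cc2[nH]c(C)c(-c3ccc(Oc4ccc(OC(F)(F)F)cc4)cc3)c(=O)c2cc1Cl` carries a 4-(trifluoromethoxy)phenyl there. In this assay compound 3 gives > 10000 nM, likewise a limit, so compound 3 stands at the same limit as its two neighbours.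

The three measured steps, a step that the two limits leave unreadable from compound 1 to compound 2, a step that the two limits leave unreadable from compound 1 to compound 3 and a step that the two limits leave unreadable from compound 2 to compound 3, cannot be sized, because of the limit of > 10000 nM in this assay, at which 3 of the 3 values shown sit. None of them therefore shows any step beyond the scatter.

Compound 4 `COc1cc2[nH]c(C)c(-c3ccc(Oc4ccc(C(F)(F)F)cn4)cc3)c(=O)c2cc1Cl` has not yet been measured. It differs from compound 3 as follows: 5-(trifluoromethyl)pyridin-2-yl in place of 4-(trifluoromethoxy)phenyl on an oxygen on an aromatic ring. The measured steps that change the aryl group on the ether oxygen all stayed at the limit, so the step that the limit leaves unreadable from compound 3 to compound 4 is expected to be none beyond the scatter in this assay. Compound 4 is therefore estimated at 20000 nM, within 10000 nM to 60000 nM, most likely reported only as a limit.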

Compound 4, half-maximal inhibitory concentration: > 10000 nM
Compound 4 was reported as a limit; the forecaster's own chance of this, stated with the estimate: 85%; the middle value is on the limit's open side.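

No size can be read for the steps that lead to compound 4 from compound 1, compound 2 or compound 3, because each pair shares a single limit: the limit of > 10000 nM in this assay, at which 4 of the 4 values shown sit. The compounds shown leave open what number each of the four would give in this assay, and so whether the group on the ether oxygen matters there at all.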